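This account rests on a few compounds, and the source may have more. Where it says the series, first, only, none or still open, it means among the compounds named here.

Measured so far in a functional assay on HeLa cells (Homo sapiens) for antiproliferative activity, with a stated time of 24 h; on this read-out higher numbers stand for weaker inhibition and lower numbers for stronger inhibition:
Compound 1, `NC(=O)c1c(NC(=O)c2ccccc2Cl)sc2c1CCN(Cc1ccccc1)C2`: 38400 nM
Compound 2, `NC(=O)c1c(NC(=O)c2ccccc2Cl)sc2c1CCN(Cc1ccccc1F)C2`: > 50000 nM
Compound 3, `NC(=O)c1c(NC(=O)c2ccccc2)sc2c1CCN(C(=S)Nc1ccccc1Cl)C2`: > 50000 nM

Compound 1 gives a number in this assay. For compound 2 the value is a limit of the assay, not a number. For compound 3 the value is likewise a limit. The change from compound 1 to compound 2 is fluoro in place of hydrogen on an aromatic carbon and it made an at least 1.3-fold higher number from compound 1 to compound 2 (0.11 log units; that floor lies within the scatter); the size of that step is bounded because compound 2 sits at the limit of > 50000 nM in this assay, at which 2 of the 3 values shown sit. Compound 3 differs from compound 1 in more than one place; the difference between the two cores is not broken down here.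

Compound 4, `NC(=O)c1c(NC(=O)c2ccccc2F)sc2c1CCN(C(=S)Nc1ccccc1Cl)C2`, is not yet measured. It differs from compound 3 by fluoro in place of hydrogen on an aromatic carbon, the same change as from compound 1 to compound 2, at the same place on the ring. Since compound 3 already stands at the limit of > 50000 nM in this assay, at which 2 of the 3 values shown sit, the step is expected to be a step that the limit leaves unreadable from compound 3 to compound 4, resting on the earlier step and on the limit. Compound 4 is therefore estimated at 70000 nM, with a range from 40000 nM to 150000 nM, and most likely only a limit will be reported.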

Compound 4, half-maximal inhibitory concentration: 19400 nM
Compound 4: middle estimate off by 3.6-fold (0.56 log units), on the high side; measured number below the stated range.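

In this assay, fluoro in place of hydrogen gave an at least 2.5-fold lower number from compound 3 to compound 4 (0.41 log units; beyond the scatter), and this step does not match the earlier one on the other core: the same change on two cores in this assay, an at least 1.3-fold higher number (0.11 log units; that floor lies within the scatter) from compound 1 to compound 2 and an at least 2.5-fold lower number (0.41 log units; beyond the scatter) from compound 3 to compound 4, at least 3.3-fold (0.52 log units) apart, beyond the scatter of two such steps. The true size of both steps remains unreadable, since one compound in each pair stands at a limit of the assay: the limit of > 50000 nM in this assay, at which 2 of the 4 values shown sit. The two pairs show that the outcome of this change did not carry over from one core to the other, but they do not show which of the several differences between the cores accounts for this, and one pair per core gives no general rule for the series.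

As far as these compounds go, it remains open whether the lower number for compound 4 is specific to fluoro or would also appear with a methoxy or trifluoromethyl group in the same place. Also open, from the compounds shown here alone, is how the core of compound 3 would respond to an amine or a carboxylic acid on that ring.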